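This account rests on a few compounds, and the source may have more. Where it says the series, first, only, none or still open, it means among the compounds named here.

Compound 1 `COc1cc2c(Nc3nc4ccc(C(=O)Nc5c(C)cccc5C)cc4s3)ncnc2cc1OCCCN1CCCCC1` gives 13700 nM in a functional assay on K562 cells (Homo sapiens) for cytotoxicity, read by WST assay, with a stated time of 72 h; a lower number here means a stronger inhibitor, a higher number a weaker inhibitor. Among the three compounds measured so far it stands second highest: compound 2 `COc1cc2c(Nc3nc4ccc(C(=O)Nc5c(C)cccc5C)cc4s3)ncnc2cc1OCCCN1CCCCC1C` gives 12300 nM, and compound 3 `COc1cc2c(Nc3nc4ccc(C(=O)Nc5c(C)cccc5C)cc4s3)ncnc2cc1OCCCN1CCC(C)CC1` gives 15800 nM. The step of a 1.1-fold lower number from compound 1 to compound 2 (0.05 log units; within the scatter) and the step of a 1.2-fold higher number from compound 1 to compound 3 (0.06 log units; within the scatter) both place a methyl on a saturated ring carbon, and the step of a 1.3-fold higher number from compound 2 to compound 3 (0.11 log units; within the scatter) exchanges 2-methylpiperidin-1-yl for 4-methylpiperidin-1-yl; all three stay within the scatter. Compound 4 `COc1cc2c(Nc3nc4ccc(C(=O)Nc5c(C)cccc5Cl)cc4s3)ncnc2cc1OCCCN1CCCCC1` differs from compound 1 elsewhere in the molecule: chloro in place of methyl on an aromatic carbon. Among the measured compounds shown here, none of the measured steps touches the 2,6-dimethylphenyl part, so no step bears directly on this change, and the data offer no direction for it. Compound 4 is therefore expected to stay close to compound 1, with an estimated step of a 1.1-fold lower number from compound 1 to compound 4 (0.06 log units; within the scatter). For the measured compounds named here, the estimate for compound 4 is 12000 nM, with a range from 4500 nM to 32000 nM, wider than usual since no measured step informs it.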

Compound 4, half-maximal inhibitory concentration: 12500 nM
Estimate against measurement, compound 4: 1.0-fold (0.02 log units) below; the measured number falls inside the stated range.
By their numbers in this assay, from the lowest: compounds 2, 4, 1 and 3 (each within the scatter of the next).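

Earlier steps changed only the piperidin-1-yl group on the chain, so compound 4 gives the first reading from a different part of the molecule. In this assay the step of a 1.1-fold lower number from compound 1 to compound 4 (0.04 log units; within the scatter) shows that 2-chloro-6-methylphenyl in place of 2,6-dimethylphenyl cannot be told apart from the parent, so on this aromatic carbon, ortho to a large group, chloro and methyl read alike. No measurement at hand offers a reason for this result.

Still open, on these data alone, is whether a larger or different group on this carbon, such as methoxy, trifluoromethyl or an amine, would move the number beyond the scatter. As far as these compounds go, it is also open whether any change to the shared core or the chain, such as a morpholine in place of the piperidine or a longer chain, would separate compounds in this assay.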